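A few compounds are considered here, and "the series" means these few. Any claim that something is new, unique, unknown or untested is made for them only; others in the source may bear on it.

Compound 1 `c1ccc2c(c1)CN[C@@H](CN(CCCCNCc1ccncc1)[C@H]1CCCc3cccnc31)C2` is the reference point of this small set. In a functional assay on cells for antagonist activity at C-X-C chemokine receptor type 4 (Homo sapiens), read by fluorescence and calcium flux, with stated times of 25 min and 90 s (on this read-out higher numbers stand for weaker inhibition and lower numbers for stronger inhibition), compound 1 gives 22.7 nM, the lowest of the three numbers measured. Compound 2 `c1ccc2c(c1)CN[C@@H](CN(CCCCNCC1CCCCC1)[C@H]1CCCc3cccnc31)C2` gives 158 nM, and compound 3 `CC(C)(CN)CCN(C[C@H]1Cc2ccccc2CN1)[C@H]1CCCc2cccnc21` gives 69 nM. The step of a 7.0-fold higher number from compound 1 to compound 2 (0.84 log units; beyond the scatter) shows that swapping the aromatic ring for a saturated one costs potency, while a 3.0-fold higher number from compound 1 to compound 3 (0.48 log units; beyond the scatter) shows that shortening the side arm also costs some, and a 2.3-fold lower number from compound 2 to compound 3 (0.36 log units; beyond the scatter) lies between them.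

Compound 4 `C(=C/CN(C[C@H]1Cc2ccccc2CN1)[C@H]1CCCc2cccnc21)\CNCc1ccccn1` differs from compound 1 as follows: a group of 11 heavy atoms (9 carbon, 2 nitrogen; one six-membered aromatic ring with 1 hetero atom) in place of a group of 11 heavy atoms (9 carbon, 2 nitrogen; one six-membered aromatic ring with 1 hetero atom), on a saturated chain carbon bound to an amine nitrogen. The group that enters keeps the six-membered aromatic ring with one hetero atom, but carries one double bond outside aromatic rings. Among the compounds with values here, none of the measured steps tests this exact change; the closest, the step from compound 1 to compound 2, removed the aromatic ring entirely, which compound 4 does not. He therefore expects a step in this assay smaller than that, somewhat toward weaker inhibition, a 2.0-fold higher number from compound 1 to compound 4 (0.30 log units; within the scatter). His estimate for compound 4 is 45 nM, within 15 nM to 140 nM.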

Compound 4, half-maximal inhibitory concentration: 58.3 nM
Compound 4: the middle estimate sits 1.3-fold (0.11 log units) below what was measured; measured number inside the range.
By their numbers in this assay, from the lowest: compound 1; then compounds 4 and 3 (each within the scatter of the next); then compound 2.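

In this assay, the group that enters at this place, on a saturated chain carbon bound to an amine nitrogen, matches the one it replaces in heavy atoms and keeps the aromatic ring, yet the change still gives a 2.6-fold higher number from compound 1 to compound 4 (0.41 log units; beyond the scatter). The aromatic ring does not secure the potency of compound 1 by itself, although the comparison with a cyclohexyl-bearing chain gives a 2.7-fold lower number from compound 2 to compound 4 (0.43 log units; beyond the scatter). The step of a 1.2-fold lower number from compound 3 to compound 4 (0.07 log units; within the scatter) puts this ring-bearing group level with the ringless side arm of compound 3, and nothing shown gives a reason for these differences.

On these data alone, what stays open is whether the double bond alone accounts for the step from compound 1. As far as these compounds go, how a phenyl or pyridin-3-yl group would fare on either chain also remains open.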